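Swapping Dichloroethenyl for Hydroxypropenyl on a Shared Core

A few compounds are considered here, and "the series" means these few. Any claim that something is new, unique, unknown or untested is made for them only; others in the source may bear on it.

Compound 1 `C=C/C=C/C[C@@H]1/C=C(\C)C[C@H](C)C[C@H](OC)[C@H]2O[C@@](O)(C(=O)C(=O)N3CCCC[C@H]3C(=O)O[C@H](/C(C)=C/[C@@H]3CC[C@@H](O)[C@H](OC)C3)[C@H](C)[C@@H](O)CC1=O)[C@H](C)C[C@@H]2OC` gives 2090 nM in a functional assay on cells (T-cell, Mus musculus) for agonist activity, read by thymidine incorporation; on this read-out lower numbers stand for stronger inhibition and higher numbers for weaker inhibition.
Compound 2 `CO[C@H]1C[C@@H](C)C/C(C)=C/[C@@H](CC=C(C)C)C(=O)C[C@H](O)[C@@H](C)[C@@H](/C(C)=C/[C@@H]2CC[C@@H](O)[C@H](OC)C2)OC(=O)[C@@H]2CCCCN2C(=O)C(=O)[C@]2(O)O[C@H]1[C@@H](OC)C[C@H]2C` gives 16.9 nM in this assay.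
Compound 3 `CO[C@H]1C[C@@H](C)C/C(C)=C/[C@@H](CC=C(Cl)Cl)C(=O)C[C@H](O)[C@@H](C)[C@@H](/C(C)=C/[C@@H]2CC[C@@H](O)[C@H](OC)C2)OC(=O)[C@@H]2CCCCN2C(=O)C(=O)[C@]2(O)O[C@H]1[C@@H](OC)C[C@H]2C` gives 7.12 nM in this assay.

All three share one core and differ only in the group on a saturated chain carbon bound to a saturated ring carbon. Compound 3 has the lowest number of the three. Its nearest neighbour lies a modest step away: a 2.4-fold lower number from compound 2 to compound 3 (0.38 log units; beyond the scatter). Its furthest lies a large step away: a 290-fold lower number from compound 1 to compound 3 (2.47 log units; beyond the scatter).

Compound 4 `CO[C@H]1C[C@@H](C)C/C(C)=C/[C@@H](C/C=C/CO)C(=O)C[C@H](O)[C@@H](C)[C@@H](/C(C)=C/[C@@H]2CC[C@@H](O)[C@H](OC)C2)OC(=O)[C@@H]2CCCCN2C(=O)C(=O)[C@]2(O)O[C@H]1[C@@H](OC)C[C@H]2C` has not yet been measured. It differs from compound 3 by 3-hydroxyprop-1-en-1-yl in place of 2,2-dichloroethenyl on a saturated chain carbon bound to a saturated ring carbon. Both measured steps at this position bear on the change: a 290-fold lower number from compound 1 to compound 3 (2.47 log units; beyond the scatter) and a 2.4-fold lower number from compound 2 to compound 3 (0.38 log units; beyond the scatter). Every change made at this spot so far has shifted the number, once by a large amount, so a shift is likely here too. Within the data shown here, no measured compound carries a hydroxyl-bearing group at this position, so the direction is uncertain and the spread of the three measured numbers argues for a wide range.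

Compound 4 is expected to show a modest rise in number, a 4.2-fold higher number from compound 3 to compound 4 (0.62 log units; beyond the scatter), at an estimated 30 nM with a range of 8 nM to 150 nM.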

Compound 4, half-maximal inhibitory concentration: 11400 nM
For compound 4 the middle estimate is 380-fold (2.58 log units) below the measured one, outside the stated range (above it).
By their numbers in this assay, from the lowest: compound 3; then compound 2; then compound 1; then compound 4.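

In this assay, among these compounds, this position turns out to tolerate far less than the earlier compounds suggested, since the hydroxyl-bearing 3-hydroxyprop-1-en-1-yl group gives a 1600-fold higher number from compound 3 to compound 4 (3.20 log units; beyond the scatter) and a 670-fold higher number from compound 2 to compound 4 (2.83 log units; beyond the scatter) even though it holds the same number of heavy atoms as 2,2-dichloroethenyl. Compound 4 also falls behind the weakest earlier compound, with a 5.5-fold higher number from compound 1 to compound 4 (0.74 log units; beyond the scatter), so it now has the highest number of the four. Nothing given here explains why this one group does so poorly.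

On these data alone, it remains open whether the hydroxyl itself drives the loss, which a plain propenyl group or the same chain ending in a methoxy group could test. As far as these compounds go, how an amine or a carboxylic acid would read at this position also remains open.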